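The source may hold more compounds than are shown below. What is called first, only, known or untested is meant among the compounds shown, and "the series" means these compounds.

Measured in an ADME assay on HEL cells (Homo sapiens) for cytotoxicity, with a stated time of 3 days; on this read-out higher numbers stand for lower toxicity in this test and lower numbers for higher toxicity in this test: compound 1 `Cc1cc(-c2cccc(F)c2)c2ncc(CSCCc3ccccc3)n2c1` gives 35 ug/mL. Compound 2 `Cc1cc(-c2cccs2)cn2c(CSCCc3ccccc3)cnc12` gives 32 ug/mL. Compound 3 `Cc1cc(-c2ccc(C#N)cc2)cn2c(CSCCc3ccccc3)cnc12` gives 10.6 ug/mL.

Going by the values given here, compound 1 and compound 2 sit within the scatter of each other; compound 3 lies beyond the scatter below both, the only step between measured neighbours being a 3.0-fold lower number from compound 2 to compound 3 (0.48 log units; beyond the scatter). Compound 4 `Cc1cc(I)c2ncc(CSCCc3ccccc3)n2c1` differs from compound 1 by iodo in place of 3-fluorophenyl on an aromatic carbon. Among the compounds with values here, no measured step exchanges an aromatic ring for a halogen, so the single known step, which swaps one aromatic ring for another on an aromatic carbon, bears on it only loosely; it shows that change at this point moves the number modestly. The expectation for compound 4 is therefore a step within the scatter or slightly downward, a 1.3-fold lower number from compound 1 to compound 4 (0.10 log units; within the scatter). Compound 4 is estimated at 28 ug/mL, range 12 ug/mL to 65 ug/mL.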

Compound 4, half-maximal cytotoxic concentration: > 50 ug/mL
Compound 4 gave a limit, no number (the forecaster's own chance of this, stated with the estimate: 15%); middle value at least 1.7-fold (0.25 log units) from the limit.
By their numbers in this assay, from the lowest: compound 3; then compounds 2 and 1 (each within the scatter of the next). At a limit, above all of these: compound 4.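

In this assay, iodo in place of 3-fluorophenyl on this aromatic carbon gives an at least 1.4-fold higher number from compound 1 to compound 4 (0.15 log units; that floor lies within the scatter). The entry for compound 4 is a limit, not a number: the limit of > 50 ug/mL in this assay, at which 1 of the 4 values shown sits. The earlier ring-for-ring step showed only a change between aromatic rings, whereas this one shows that the number does not fall when the ring leaves this position, though its floor lies within the scatter and no rise is established.

As far as these compounds go, how far compound 4 lies beyond its limit remains open. Also open, from the compounds shown here alone, is how an amine, a carboxylic acid or a longer chain on this carbon would read.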